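A Propyl Chain in Place of Methoxyphenyl

A few compounds are considered here, and "the series" means these few. Any claim that something is new, unique, unknown or untested is made for them only; others in the source may bear on it.

Two compounds share one core and differ only in the group hanging from the oxygen-linked side chain. Compound 1 `[O-][n+]1nc(NCOCc2ccccc2)[n+]([O-])c2ccccc21` is the parent; in a functional assay on KB cells (Homo sapiens) for cytotoxicity, read by MTT assay, with a stated time of 72 h (on this read-out lower numbers stand for stronger inhibition and higher numbers for weaker inhibition), compound 1 gives 5720 nM. Compound 2 `COc1ccc(COCNc2n[n+]([O-])c3ccccc3[n+]2[O-])cc1` puts a methoxy in place of hydrogen on an aromatic carbon, and in this assay compound 2 gives 4060 nM. The step of a 1.4-fold lower number from compound 1 to compound 2 (0.15 log units; within the scatter) is too small to count as a real change, so on the numbers shown compound 2 and compound 1 cannot be told apart.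

Compound 3 `CCCCOCNc1n[n+]([O-])c2ccccc2[n+]1[O-]` makes a larger move: propyl in place of 4-methoxyphenyl on a saturated chain carbon bound to an oxygen on a saturated carbon. The whole 4-methoxyphenyl leaves and a propyl enters at the same place. Within the data shown here, the single measured step only added a methoxy to a ring that stayed in place; nothing measured here speaks to removing that ring altogether. The expectation for compound 3 therefore rests on compound 2 alone and carries a wide range. The step of a 1.5-fold higher number from compound 2 to compound 3 (0.17 log units; within the scatter) is what is expected, and compound 3 is estimated at 6000 nM, between 2500 nM and 15000 nM.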

Compound 3, half-maximal inhibitory concentration: 1750 nM
Beside the measured number, compound 3's estimate is 3.4-fold (0.54 log units) above it; the whole stated range lies above it.
By their numbers in this assay, from the lowest: compound 3; then compounds 2 and 1 (each within the scatter of the next).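

The ring itself turns out not to be needed at this place, on a saturated chain carbon bound to an oxygen on a saturated carbon: in this assay putting propyl in place of 4-methoxyphenyl gives a 2.3-fold lower number from compound 2 to compound 3 (0.37 log units; beyond the scatter) and putting propyl in place of phenyl gives a 3.3-fold lower number from compound 1 to compound 3 (0.51 log units; beyond the scatter) on the same side chain. The earlier methoxy step left the ring in place and stayed within the scatter, whereas these two steps, though modest, lie beyond it and show that a chain with no ring and fewer heavy atoms gives a lower number than either ring-bearing group. Nothing available here offers a reason for this drop.

The compounds shown leave open whether the lower number belongs to propyl in particular or extends to other open chains, such as a longer hexyl chain, a branched isopropyl group, or a propyl chain ending in an amine or a carboxylic acid. All three compounds also carry the shared core, so whether the step from a ring to a propyl chain would hold on a different core remains an open question.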